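Oxime ether chain variation in a thioether series

The source may hold more compounds than are shown below. What is called first, only, known or untested is meant among the compounds shown, and "the series" means these compounds.

Measured so far in a functional assay (blood) for inhibition, with Homo sapiens as the target; a lower number here means a stronger inhibitor, a higher number a weaker inhibitor:
compound 1 `COC1(c2cc(F)cc(Sc3ccc4c(c3)CC/C4=N\OCC#N)c2)CCOCC1` gives 30 nM
compound 2 `C/C(=N\OCCSc1nnc(C)s1)c1ccc(Sc2cc(F)cc(C3CCOCC3)c2)cc1` gives 230 nM
compound 3 `C/C(=N\OCCF)c1ccc(Sc2cc(F)cc(C3CCOCC3)c2)cc1` gives 40 nM

Compound 3 sits second highest of the three numbers in this assay; its nearest neighbour is compound 1, whose value lies within the scatter of that of compound 3, while compound 2 sits beyond the scatter on the high side. Within the data shown here, the one step available on the oxime ether chain is a 5.8-fold lower number from compound 2 to compound 3 (0.76 log units; beyond the scatter), a modest move to a lower number when a sulfur-linked heteroaromatic group on the chain is replaced by fluoro.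

Compound 4 `C/C(=N\OCc1ccncc1)c1ccc(Sc2cc(F)cc(C3CCOCC3)c2)cc1` differs from compound 3 by pyridin-4-yl in place of fluoromethyl on a saturated chain carbon bound to an oxygen. This step bears on that of compound 2 to compound 3 only loosely: there a heteroaromatic group left and the number fell; here a heteroaromatic ring enters, though bound directly to the chain and without the sulfur link. Compound 4 is therefore expected to move to a higher number in this assay, by an estimated 2.3-fold higher number from compound 3 to compound 4 (0.35 log units; beyond the scatter), a smaller move than the earlier step. The estimate for compound 4 in this assay is 90 nM, with a range from 30 nM to 270 nM.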

Compound 4, half-maximal inhibitory concentration: 300 nM
Estimate against measurement, compound 4: 3.3-fold (0.52 log units) below; measured number outside the range, above it.
By their numbers in this assay, from the lowest: compounds 1 and 3 (each within the scatter of the next); then compounds 2 and 4 (each within the scatter of the next).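

In this assay, the position on the saturated chain carbon bound to an oxygen also responds to a heteroaromatic ring that carries no sulfur link: pyridin-4-yl in place of fluoromethyl gives a 7.5-fold higher number from compound 3 to compound 4 (0.88 log units; beyond the scatter) and leaves compound 3 with the lower number. The higher number in compound 2 is thus not confined to the (5-methyl-1,3,4-thiadiazol-2-yl)sulfanyl group, as a 1.3-fold higher number from compound 2 to compound 4 (0.12 log units; within the scatter) places the two ring-bearing chains within the scatter of each other. No measurement on hand accounts for this shift.

Going by these compounds, whether a plain phenyl ring on the same chain carbon would behave like pyridin-4-yl or like fluoromethyl remains open. So does the standing of an amine or a carboxylic acid at the end of a longer chain on the shared core.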